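The compounds below may be only part of what the source reports. "The series", "measured", "known", "first", "only" and "open" are said of these compounds alone.

Working notes on the series. Compound 1 `COc1ccccc1-c1n[nH]cc1N1CCCNCC1` and compound 2 `c1ccc(-c2n[nH]cc2N2CCCNCC2)cc1` share one core; compound 2 carries hydrogen in place of methoxy on an aromatic carbon. In an assay on isolated protein for binding affinity to 5-hydroxytryptamine receptor 4 (Homo sapiens) (on this read-out higher numbers stand for weaker inhibition and lower numbers for stronger inhibition), compound 1 gives > 10000 nM, which is a limit of the assay and not a number. In this assay compound 2 gives > 10000 nM, again a limit. The step that the two limits leave unreadable from compound 1 to compound 2 cannot be sized because of the limit of > 10000 nM in this assay, at which 3 of the 3 values shown sit.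

Compound 3 `COc1ccc(-c2n[nH]cc2N2CCNCC2)cc1` rests on another core; the difference between the two cores is not broken down here. In this assay compound 3 gives > 10000 nM, a limit as well. Compound 4 `c1ccc(-c2n[nH]cc2N2CCNCC2)cc1` is not yet measured and differs from compound 3 by hydrogen in place of methoxy on an aromatic carbon. This is the same kind of change as that between compound 1 and compound 2, though not the same: there the place is ortho to a large group, here it is para to a large group.

Both measured pairs sit at the limit of > 10000 nM in this assay, at which 3 of the 3 values shown sit, so the earlier step gives no size to lean on. The expected step is a step that the limit leaves unreadable from compound 3 to compound 4, resting on (the limit of > 10000 nM in this assay, at which 3 of the 3 values shown sit). Compound 4 is expected to give about 20000 nM, between 5000 nM and 80000 nM, most probably reported again only as a limit.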

Compound 4, inhibition constant: > 10000 nM
Compound 4: only a limit was reported; the forecaster's own chance of this, stated with the estimate: 85%; the middle value lies beyond the limit too.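

No step can be read from compound 3 to compound 4 in this assay, since both values are limits of the assay and not numbers: the limit of > 10000 nM in this assay, at which 4 of the 4 values shown sit.

The compounds shown leave open what number any of the four would give in this assay, and whether hydrogen in place of methoxy makes any difference there.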